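Adding a second methoxy to a series at its limit

This account rests on a few compounds, and the source may have more. Where it says the series, first, only, none or still open, it means among the compounds named here.

Measured so far, every value a limit:
- compound 1 `C=C1CC[C@H]2C(C)(C)CCC[C@]2(C)[C@H]1CCC(C)CC(=O)OC`: > 200000 nM
- compound 2 `COc1ccc(/C=C2\CC[C@H]3C(C)(C)CCC[C@]3(C)[C@H]2CCC(C)CC(=O)O)cc1`: > 200000 nM
- compound 3 `Cc1ccc(/C=C2\CC[C@H]3C(C)(C)CCC[C@]3(C)[C@H]2CCC(C)CC(=O)O)cc1`: > 200000 nM

In a functional assay on THP-1 cells (Homo sapiens) for cytotoxicity, read by MTT assay, with a stated time of 24 h (on this read-out lower numbers stand for stronger inhibition and higher numbers for weaker inhibition), compound 2 gives > 200000 nM, which is a limit and not a number. The series as a whole stands at the limit of > 200000 nM in this assay, at which 3 of the 3 values shown sit. Compound 4 `COc1ccc(/C=C2\CC[C@H]3C(C)(C)CCC[C@]3(C)[C@H]2CCC(C)CC(=O)O)cc1OC` follows from compound 2 by methoxy in place of hydrogen on an aromatic carbon, 4-methoxyphenyl to 3,4-dimethoxyphenyl. Within the data shown here, the one measured step that bears on this change is a step that the two limits leave unreadable from compound 2 to compound 3, so it offers no size to carry over. No step beyond the scatter can be expected, and no direction is favoured. The estimated change is a number no higher from compound 2 to compound 4 (the limit leaves the size open). Compound 4 is expected at about 200000 nM, with an estimated range of 100000 nM to 400000 nM.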

Compound 4, half-maximal inhibitory concentration: 178000 nM
The estimate for compound 4 lay 1.1-fold (0.05 log units) above the measured number; the measured number falls inside the stated range.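

In this assay, among these compounds, compound 4 is the first member of the series to give a number and not a limit. Adding the second methoxy is an at least 1.1-fold lower number from compound 2 to compound 4 (0.05 log units; that floor lies within the scatter), and replacing 4-methylphenyl with 3,4-dimethoxyphenyl is an at least 1.1-fold lower number from compound 3 to compound 4 (0.05 log units; that floor lies within the scatter); neither floor establishes a step beyond the scatter. The series remains largely at its limit: the limit of > 200000 nM in this assay, at which 3 of the 4 values shown sit.

On these data alone, the actual size of both steps remains open, as the values for compound 2 and compound 3 are limits. Also open, as far as these compounds go, is how an amine or a hydroxy group on this aromatic carbon would read.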